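The compounds below may be only part of what the source reports. "The series", "measured", "known", "first", "only" and "open" are said of these compounds alone.

Measured compounds:
- compound 1, `O=S(=O)(c1cccc(-c2ccc3nccc(-c4ccncc4)c3n2)c1)N1CCC(O)CC1`, gives 7% in an ADME assay on microsomes from liver (Mus musculus) for metabolic stability, read by LC-MS, using NADPH, with a stated time of 30 min, tested at 0.1 uM; on this read-out higher numbers stand for a more stable compound and lower numbers for a less stable compound
- compound 2, `O=S(=O)(NCC1COC1)c1cccc(-c2ccc3nccc(-c4ccncc4)c3n2)c1`, gives 19% in this assay
- compound 3, `O=S(=O)(NCc1ccccc1)c1cccc(Nc2ccc3nccc(-c4ccncc4)c3n2)c1`, gives 2% in this assay

Among these three numbers compound 2 stands highest: compound 1 is nearest to it, and compound 3 is furthest away, both differences being beyond the usual scatter. The new compound 4, `C[C@@H]1CN(S(=O)(=O)c2cccc(-c3ccc4nccc(-c5ccncc5)c4n3)c2)C[C@H](C)N1`, is reached from compound 2 by one change at the sulfonyl sulfur: 3,5-dimethylpiperazin-1-yl in place of ((oxetan-3-yl)methyl)amino on a sulfonyl sulfur.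

Going by the values given here, only one measured step bears on this change. Going from a six-membered ring amine on the sulfonyl sulfur to the open ((oxetan-3-yl)methyl)amino gave a number 12 percentage points higher from compound 1 to compound 2 (beyond the scatter). Compound 4 moves the other way, back to a six-membered ring amine on the same sulfur, though with 3,5-dimethylpiperazin-1-yl rather than 4-hydroxypiperidin-1-yl, so the earlier step is a guide but not a direct match. A modest fall in this assay is therefore expected, about a number 9 percentage points lower from compound 2 to compound 4 (within the scatter), taking compound 4 toward the region of compound 1.

Compound 4 is estimated to give 10% in this assay, within a range from 3% to 25%.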

Compound 4, percent of the compound remaining: 33%
Estimate against measurement, compound 4: 23 percentage points below; measured number above the stated range.
By their numbers in this assay, from the lowest: compounds 3 and 1 (each within the scatter of the next); then compound 2; then compound 4.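

In this assay, going by these compounds alone, a six-membered ring amine on the sulfonyl sulfur does not by itself bring a lower number: putting 3,5-dimethylpiperazin-1-yl in place of ((oxetan-3-yl)methyl)amino gives a number 14 percentage points higher from compound 2 to compound 4 (beyond the scatter), which reverses the impression left by the single earlier step. The two six-membered ring amines also stand well apart, since exchanging 4-hydroxypiperidin-1-yl for 3,5-dimethylpiperazin-1-yl gives a number 26 percentage points higher from compound 1 to compound 4 (beyond the scatter), so among these compounds ring size alone does not set the number and the atoms carried by the ring count as well. The entering group has 8 heavy atoms against 6 in the group it replaces, so a larger group on this sulfur can go together with a higher number.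

A plain piperazin-1-yl without the two methyl groups, or a morpholin-4-yl on the same sulfur, would help separate the part played by the methyl groups from that of the second ring nitrogen. Why the number rises with this change also stays open, as no measurement given here speaks to it.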